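The source may report more compounds than this note shows. Statements on the series, on what has been measured and on what is new or still open speak of the compounds shown alone.

Compound 1 `Nc1ccccc1NC(=O)c1ccc(CNC(=O)c2n[nH]cc2NC(=O)c2ccccc2)cc1` is the reference point here. Among the compounds with values here, in a functional assay on NCI-H460 cells (Homo sapiens) for inhibition, read by CCK-8 assay, with a stated time of 72 h (a higher number here means a weaker inhibitor, a lower number a stronger inhibitor), compound 1 gives 6320 nM, the lowest of the three numbers measured so far. Within the data shown here, its nearest neighbour is compound 3 `Nc1ccccc1NC(=O)c1ccc(CNC(=O)c2n[nH]cc2NC(=O)c2ccccc2Cl)cc1`, which in this assay gives 6360 nM; the step between them, a 1.0-fold higher number from compound 1 to compound 3 (0.00 log units; within the scatter), is the only single-point change measured. Compound 2 `O=C(NO)c1ccc(CNC(=O)c2n[nH]cc2NC(=O)c2ccccc2F)cc1` is the furthest away, giving 23700 nM in this assay, a gap from compound 1 that lies beyond the usual scatter, though compound 2 also differs in more than one place.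

Compound 4 `Nc1ccccc1NC(=O)c1ccc(CNC(=O)c2n[nH]cc2NC(=O)c2c(Cl)cccc2Cl)cc1` is not yet measured. It differs from compound 1 by 2,6-dichlorophenyl in place of phenyl on a carbonyl carbon, taking the benzoyl group to a (2,6-dichlorophenyl)carbonyl group. Among the measured compounds shown here, the one step that bears on this is a 1.0-fold higher number from compound 1 to compound 3 (0.00 log units; within the scatter), where a single chloro on the same ring left the number unchanged within the scatter. A second chloro is therefore expected to make little difference as well, so the estimate for compound 4 in this assay is 6500 nM, with a range from 3000 nM to 14000 nM, meaning an expected step of a 1.0-fold higher number from compound 1 to compound 4 (0.01 log units; within the scatter).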

Compound 4, half-maximal inhibitory concentration: 4190 nM
Compound 4: the middle estimate sits 1.6-fold (0.19 log units) above what was measured; low and high end bracket the measured number.
By their numbers in this assay, from the lowest: compounds 4, 1 and 3 (each within the scatter of the next); then compound 2.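

Going from phenyl to 2,6-dichlorophenyl on this carbonyl carbon gives a step within the scatter in this assay (a 1.5-fold lower number from compound 1 to compound 4 (0.18 log units; within the scatter)). Adding the second chloro to the ring of compound 3 also stays within the scatter (a 1.5-fold lower number from compound 3 to compound 4 (0.18 log units; within the scatter)). Compound 3 alone showed this for a single chloro, whereas these steps show that the ring can carry two chloro groups with no step beyond the scatter, and nothing measured here gives a reason for this.

From the compounds shown here alone, both chloro compounds keep the same ring, so it remains open whether a methoxy group or an amine on it, or a different group in its place on the carbonyl carbon, would move the number beyond the scatter. Going by these compounds, it also remains open whether a chloro or 2,6-dichlorophenyl change would behave the same way in a compound carrying the hydroxamic acid of compound 2.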